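From Bromo to Methylsulfanyl at the Assay Limit

The source may hold more compounds than are shown below. What is called first, only, known or untested is meant among the compounds shown, and "the series" means these compounds.

Of the compounds shown here, two have so far been tested in a functional assay on PC-3 cells (Homo sapiens) for cytotoxicity; a lower number here means a stronger inhibitor, a higher number a weaker inhibitor. Compound 1 `CSc1ccc(/C=N/c2nnc[nH]2)cc1` gives > 30000 nM, which is a limit of the assay and not a measured number. Compound 2 `Brc1ccc(/C=N/n2cnnc2)cc1` gives > 30000 nM, which is also only a limit. Among the compounds with values here, compound 2 therefore stands with the only other tested compound, at the limit of > 30000 nM in this assay, at which 2 of the 2 values shown sit. Within the data shown here, neither result offers an exact number for comparison, and no step between two measured compounds is available as a guide.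

Compound 3 `CSc1ccc(/C=N/n2cnnc2)cc1` differs from compound 2 in one place: methylsulfanyl in place of bromo on an aromatic carbon. This puts methylsulfanyl in place of bromo on an aromatic carbon, para to a group of 7 heavy atoms. The expectation rests on compound 2, whose result of > 30000 nM is a limit, and this single exchange gives no firm reason to expect a departure from it. The estimated change is a number no higher from compound 2 to compound 3 (the limit leaves the size open), meaning that no shift beyond the usual scatter is expected. For compound 3 the estimated value in this assay is 30000 nM, with an expected range from 10000 nM to 50000 nM.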

Compound 3, half-maximal inhibitory concentration: > 30000 nM
Compound 3 was reported as a limit (the forecaster's own chance of this, stated with the estimate: 75%); the middle value sits exactly at the limit.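

In this assay compound 3 gives only a limit, as do compound 1 and compound 2, so neither the step from compound 2 to compound 3 nor the step from compound 1 to compound 3 can be read. The compounds shown leave open whether either exchange alters potency at all, and which structure would give an exact number.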